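Thiourea aryl variation: from difluoro to fluoro-trifluoromethyl

The compounds below may be only part of what the source reports. "The series", "measured", "known", "first", "only" and "open" are said of these compounds alone.

Compounds measured so far in a functional assay on PC-3 cells (Homo sapiens) for antiproliferative activity, read by MTT assay; a higher number here means a weaker inhibitor, a lower number a stronger inhibitor:
Compound 1, `CNC(=O)c1ccc(Oc2cccc(NC(=S)Nc3ccc(Cl)cc3)c2)nc1`: 28400 nM
Compound 2, `CNC(=O)c1ccc(Oc2cccc(NC(=S)Nc3ccc(Br)c(C(F)(F)F)c3)c2)nc1`: 2670 nM
Compound 3, `CNC(=O)c1ccc(Oc2cccc(NC(=S)Nc3ccc(F)c(F)c3)c2)nc1`: 23100 nM

Compound 3 stands second highest of the three numbers. Among the compounds with values here, its nearest neighbour is compound 1, and the only step that can be read off directly, a 1.2-fold lower number from compound 1 to compound 3 (0.09 log units; within the scatter), lies within the scatter, so the two numbers tell nothing apart. Compound 2, with its bromo and trifluoromethyl groups, lies furthest from compound 3, and the gap between them is beyond the scatter.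

Compound 4, `CNC(=O)c1ccc(Oc2cccc(NC(=S)Nc3ccc(F)c(C(F)(F)F)c3)c2)nc1`, has not yet been measured. Relative to compound 3 the change is trifluoromethyl in place of fluoro on an aromatic carbon. Within the data shown here, no measured step exchanges fluoro for trifluoromethyl, so the direct evidence is missing. Among the measured compounds shown here, what the data do show is that the only compound carrying a trifluoromethyl group, compound 2, gives 2670 nM in this assay, while the compounds without it, compound 1 with 28400 nM and compound 3 with 23100 nM, sit much higher.

On that basis compound 4 is expected to move toward compound 2, with a step of about a 3.9-fold lower number from compound 3 to compound 4 (0.59 log units; beyond the scatter), though the bromo-to-fluoro difference between compound 2 and compound 4 leaves the size uncertain. The estimate for compound 4 is 6000 nM, expected to fall between 2500 nM and 15000 nM.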

Compound 4, half-maximal inhibitory concentration: 7950 nM
Beside the measured number, compound 4's estimate is 1.3-fold (0.12 log units) below it, and the stated range covers the measured number.
By their numbers in this assay, from the lowest: compound 2; then compound 4; then compounds 3 and 1 (each within the scatter of the next).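

In this assay, within the data shown here, the step of a 2.9-fold lower number from compound 3 to compound 4 (0.46 log units; beyond the scatter) gives the first direct reading of trifluoromethyl in place of fluoro at this position, ortho to a fluoro group, and that step lies beyond the scatter. The second step, a 3.0-fold higher number from compound 2 to compound 4 (0.47 log units; beyond the scatter), shows that the other halogen also matters when trifluoromethyl stays in place: with fluoro in place of bromo on an aromatic carbon, the number does not stay with that of compound 2, so trifluoromethyl alone does not bring compound 4 down to it. Nothing measured here gives a reason for either step.

The compounds shown leave open whether trifluoromethyl would give a step of the same size with bromo in the place of the remaining fluoro group, as no compound carries bromo there without trifluoromethyl. They also leave open how a nitrile, a methoxy group or an amine would read in the place now held by trifluoromethyl, and so whether this change is particular to trifluoromethyl or shared by other groups.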